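From benzofuran to a nitrogen-bearing partner on compound 1

The compounds below may be only part of what the source reports. "The series", "measured", "known", "first", "only" and "open" are said of these compounds alone.

Measured compounds:
compound 1 `Cn1c(=O)c(S(=O)(=O)c2ccc(F)cc2)cc2cnc(Nc3ccc4occc4c3)nc21`: 5000 nM
compound 2 `Cn1c(=O)c(S(=O)(=O)c2ccc(F)cc2F)cc2cnc(Nc3ccc4occc4c3)nc21`: 15000 nM
compound 3 `O=c1c(S(=O)(=O)c2ccc(F)cc2F)cc2cnc(Nc3ccc4[nH]ccc4c3)nc2n1C1CC1`: 500 nM

In a functional assay on K562 cells (Homo sapiens) for inhibition, read by trypan blue exclusion, with a stated time of 72 h (on this read-out lower numbers stand for stronger inhibition and higher numbers for weaker inhibition), compound 1 gives 5000 nM, the second highest of the three numbers. Its nearest neighbour is compound 2, reached by a 3.0-fold higher number from compound 1 to compound 2 (0.48 log units; beyond the scatter), a modest change coming from a fluoro in place of hydrogen on an aromatic carbon. Furthest away is compound 3, which gives 500 nM, a much lower number, well beyond the scatter; compound 3 differs from compound 1 in more than one place, so no single step links the two.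

Compound 4 `Cn1c(=O)c(S(=O)(=O)c2ccc(F)cc2)cc2cnc(Nc3cnc4[nH]ccc4c3)nc21` has not yet been measured. Compared with compound 1 the change is a group of 9 heavy atoms (7 carbon, 2 nitrogen; one five-membered aromatic ring with 1 hetero atom, one six-membered aromatic ring with 1 hetero atom) in place of a group of 9 heavy atoms (8 carbon, 1 oxygen; one five-membered aromatic ring with 1 hetero atom, one six-membered aromatic ring of carbon only), on a nitrogen on an aromatic ring. Going by the values given here, the one measured step, the fluoro change, touches a different part of the molecule and says nothing about this exchange. Among the compounds with values here, compound 3 is the only measured compound whose partner group carries a hydrogen-bond donor, and it gives the lowest number, but its other differences mean this is a hint, not a rule.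

The expected outcome is therefore a modest move toward a lower number, a 2.0-fold lower number from compound 1 to compound 4 (0.30 log units; within the scatter). Compound 4 is estimated at 2500 nM in this assay, with a range from 700 nM to 9000 nM.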

Compound 4, half-maximal inhibitory concentration: 750 nM
Estimate against measurement, compound 4: 3.3-fold (0.52 log units) above; measured number inside the range.
By their numbers in this assay, from the lowest: compounds 3 and 4 (each within the scatter of the next); then compound 1; then compound 2.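

In this assay, the exchange of 1-benzofuran-5-yl for the nitrogen-bearing group gives a 6.7-fold lower number from compound 1 to compound 4 (0.82 log units; beyond the scatter) with the rest of the molecule unchanged, so the group on this nitrogen affects the read-out on its own, which compound 3 could not show because it differs from compound 1 in more than one place. The exchange alters both rings of the group at once: the five-membered ring gains a hydrogen-bond donor, and the six-membered ring gains a hetero atom, so this single step cannot assign the shift to either ring. No measurement shown here explains the shift.

As far as these compounds go, it remains open which ring change matters, and a phenyl ring carrying an amine or a carboxylic acid in place of the two-ring group would test whether a second ring is needed at all. It is also unknown whether the fluoro step seen with 1-benzofuran-5-yl, a 3.0-fold higher number from compound 1 to compound 2 (0.48 log units; beyond the scatter), would hold with the new group in place.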